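Chloro substitution on the pyridyl ether core

The source may hold more compounds than are shown below. What is called first, only, known or untested is meant among the compounds shown, and "the series" means these compounds.

Measured compounds:
compound 1 `COC(=O)Nc1cc(-c2ccc(OC[C@@](C)(N)CC(C)C)cn2)ccn1` — 23 nM
compound 2 `COC(=O)Nc1cc(-c2cnc(OC[C@@](C)(N)CC(C)C)c(Cl)c2)ccn1` — 0.4 nM
compound 3 `COC(=O)Nc1cc(-c2ccc(OC[C@@](C)(N)CC(C)C)nc2)ccn1` — 28 nM

All three were run in an assay on isolated protein for inhibition of AP2-associated protein kinase 1 (Homo sapiens), with a stated time of 3 h, in the presence of a further agent that is not named here; a higher number here means a weaker inhibitor, a lower number a stronger inhibitor. Compound 1 gives 23 nM, and compound 3 gives 28 nM; these two numbers lie within the scatter of each other. The cores of compound 1 and compound 3 hold the same atoms joined differently, and that difference is not broken down here. Compound 2 gives 0.4 nM, and the step of a 70-fold lower number from compound 3 to compound 2 (1.85 log units; beyond the scatter) is the one large move in the set; the change is chloro in place of hydrogen on an aromatic carbon.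

Compound 4 `COC(=O)Nc1cc(-c2ccc(OC[C@@](C)(N)CC(C)C)c(Cl)n2)ccn1` is not yet measured. It comes from compound 1 by chloro in place of hydrogen on an aromatic carbon. This is the same kind of change as that from compound 3 to compound 2, but the place differs: in compound 4 the chloro sits next to the ring nitrogen, whereas in compound 2 it is two atoms from the ring nitrogen. Because a 70-fold lower number from compound 3 to compound 2 (1.85 log units; beyond the scatter) is large, a marked drop in number is expected for compound 4 as well, though the different place around the ring nitrogen leaves its size uncertain. The estimated step is a 15-fold lower number from compound 1 to compound 4 (1.19 log units; beyond the scatter). Compound 4 is expected to give about 1.5 nM in this assay, with a range from 0.4 nM to 8 nM.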

Compound 4, half-maximal inhibitory concentration: 0.5 nM
Compound 4: middle estimate off by 3.0-fold (0.48 log units), on the high side, within the range that was stated.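

In this assay, chloro in place of hydrogen on an aromatic carbon gives a 46-fold lower number from compound 1 to compound 4 (1.66 log units; beyond the scatter), and the size of the step carries from one core to the other: the same change on two cores in this assay, a 70-fold lower number (1.85 log units; beyond the scatter) from compound 3 to compound 2 and a 46-fold lower number (1.66 log units; beyond the scatter) from compound 1 to compound 4, 1.5-fold (0.18 log units) apart, within the scatter of two such steps Within these two matched pairs, then, the large drop in number holds on both cores, even though the chloro does not occupy the same place around the ring nitrogen. This shows transfer between these two closely related cores only, both carrying the (2-amino-2,4-dimethylpentyl)oxy group; it gives no reason for the step and does not show that the change would carry to a more distant core or to any other assay.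

Open, from the compounds shown here alone, is whether fluoro, methyl or a nitrile on the same aromatic carbon would give a step of like size, or whether the step belongs to chloro alone. Also open, going by these compounds, is whether the step would hold if a shorter chain or a cyclic amine took the place of the (2-amino-2,4-dimethylpentyl)oxy group.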